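Amino in Place of Isopropyl on the Core Nitrogen

The source may report more compounds than this note shows. Statements on the series, on what has been measured and on what is new or still open speak of the compounds shown alone.

Three compounds have been measured in an assay on CHO cells for displacement of a labelled ligand from adenosine receptor A1 (Homo sapiens), read by scintillation counting, with a stated time of 90 min; on this read-out higher numbers stand for weaker inhibition and lower numbers for stronger inhibition:
Compound 1 `CCn1nc(-c2ccccn2)c2sccc2c1=O` gives 782 nM
Compound 2 `CC(C)n1nc(-c2ccccn2)c2sccc2c1=O` gives 912 nM
Compound 3 `CCn1nc(-c2nccs2)c2sccc2c1=O` gives 113 nM

Compound 2 shows the highest number of the three. Its nearest neighbour is compound 1, from which it differs by a 1.2-fold higher number from compound 1 to compound 2 (0.07 log units; within the scatter); its values sit furthest from those of compound 3. Compound 4 `Nn1nc(-c2ccccn2)c2sccc2c1=O` is obtained by one change: amino in place of isopropyl on an aromatic nitrogen. Of the measured steps, only the chain change on the same nitrogen bears on this, and it was small: a 1.2-fold higher number from compound 1 to compound 2 (0.07 log units; within the scatter). The step of a 6.9-fold lower number from compound 1 to compound 3 (0.84 log units; beyond the scatter) alters a different group and says nothing here. Going by the values given here, no measured pair exchanges an alkyl for an amino at this position, so the expectation rests on the chain step alone and is uncertain. Compound 4 is therefore expected to stay near compound 2, with a step of about a 1.1-fold higher number from compound 2 to compound 4 (0.04 log units; within the scatter). The estimate for compound 4 is 1000 nM, within a range from 300 nM to 3500 nM.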

Compound 4, inhibition constant: 3720 nM
The estimate for compound 4 lay 3.7-fold (0.57 log units) below the measured number; measured number outside the range, above it.
By their numbers in this assay, from the lowest: compound 3; then compounds 1 and 2 (each within the scatter of the next); then compound 4.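

The position is far less tolerant of amino than of a change in chain size: in this assay, ethyl and isopropyl stay within the scatter of each other, whereas amino brings both a 4.1-fold higher number from compound 2 to compound 4 (0.61 log units; beyond the scatter) and a 4.8-fold higher number from compound 1 to compound 4 (0.68 log units; beyond the scatter) (a higher number here meaning weaker inhibition). The step thus depends on what enters and not only on the size of the group, since the smaller amino does not match ethyl. Nothing shown accounts for this loss.

On these data alone, whether a methylamino or dimethylamino group on this nitrogen would behave like amino or like the alkyl chains remains open. So does whether amino would produce a similar step alongside the 1,3-thiazol-2-yl group of compound 3.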